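The source may hold more compounds than are shown below. What is called first, only, known or untested is meant among the compounds shown, and "the series" means these compounds.

In a functional assay on Hep cells (Homo sapiens) for cytotoxicity, read by sulforhodamine B assay, with a stated time of 48 h (a lower number here means a stronger inhibitor, a higher number a weaker inhibitor), compound 2 `C=CCOc1ccc(Br)cc1C(=O)c1cccnc1` gives 78000 nM, the highest number of the series, against compound 1 `O=C(c1cccnc1)c1ccccc1O` at 31000 nM and compound 3 `O=C(c1cccnc1)c1cc(Br)ccc1O` at 29000 nM. Compound 4 `C=CCOc1ccccc1C(=O)c1cccnc1` differs from compound 2 by one change: hydrogen in place of bromo on an aromatic carbon. The closest measured precedent is the same exchange in the opposite direction, a 1.1-fold lower number from compound 1 to compound 3 (0.03 log units; within the scatter). The other measured step, a 2.7-fold lower number from compound 2 to compound 3 (0.43 log units; beyond the scatter), concerns the allyl on oxygen, which compound 4 retains. No step beyond the scatter is therefore expected in this assay. The estimated change is a 1.0-fold lower number from compound 2 to compound 4 (0.02 log units; within the scatter). For compound 4 the estimated value is 75000 nM, with an expected range of 40000 nM to 140000 nM.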

Compound 4, half-maximal inhibitory concentration: > 100000 nM
Compound 4: no number, only a limit; the forecaster's own chance of this, stated with the estimate: 15%; at least 1.3-fold (0.12 log units) between middle value and limit.
By their numbers in this assay, from the lowest: compounds 3 and 1 (each within the scatter of the next); then compound 2. At a limit, above all of these: compound 4.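

In this assay compound 4 gives only a limit, > 100000 nM. Exchange of the bromo para to the allyloxy group gives an at least 1.2-fold higher number from compound 2 to compound 4 (0.10 log units; that floor lies within the scatter), so the exchange has no demonstrated size on the allyl core, and a larger one is not excluded: the same change on two cores in this assay, a 1.1-fold lower number (0.03 log units; within the scatter) from compound 1 to compound 3 and an at least 1.2-fold lower number (0.10 log units; that floor lies within the scatter) from compound 4 to compound 2; the limit leaves it open whether they differ. The allyl on oxygen now also gives a step without the bromo, an at least 3.2-fold higher number from compound 1 to compound 4 (0.50 log units; beyond the scatter), and on both cores that step lies beyond the scatter: the same change on two cores in this assay, a 2.7-fold lower number (0.43 log units; beyond the scatter) from compound 2 to compound 3 and an at least 3.2-fold lower number (0.50 log units; beyond the scatter) from compound 4 to compound 1; the limit leaves it open whether they differ.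

On these data alone, how far compound 4 lies past its limit remains open, and with it the true size of the bromo exchange on this core. Also open, as far as these compounds go, is whether a chloro or an amine at this place, or a longer chain in place of the allyl, would shift the number.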